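A few compounds are considered here, and "the series" means these few. Any claim that something is new, unique, unknown or untested is made for them only; others in the source may bear on it.

Compound 2 `O=C(NCc1ccc(S(=O)(=O)N2CCCCC2)cc1)c1cc2ccncc2[nH]1` gives 1000 nM in an assay for inhibition of Nicotinamide phosphoribosyltransferase (Homo sapiens), read by mass spectrometry, with stated times of 15 min and 30 min; on this read-out lower numbers stand for stronger inhibition and higher numbers for weaker inhibition. Among the three measured compounds it stands second highest on these numbers. Compound 3 `O=C(NCc1ccc(S(=O)(=O)c2ccccc2)cc1)c1c[nH]c2ccncc12` gives 1900 nM in this assay, which lies within the usual scatter of compound 2. Compound 1 `O=C(NCc1ccc(S(=O)(=O)c2ccccc2C(F)(F)F)cc1)c1cc2cnccc2[nH]1` gives 24 nM in this assay, far lower than compound 2 and beyond the scatter. Compound 4 `O=C(NCc1ccc(S(=O)(=O)N2CCCCC2)cc1)c1cc2cccnc2s1` has not yet been measured; it differs from compound 2 in a group of 9 heavy atoms (7 carbon, 1 nitrogen, 1 sulfur; one five-membered aromatic ring with 1 hetero atom, one six-membered aromatic ring with 1 hetero atom) in place of a group of 9 heavy atoms (7 carbon, 2 nitrogen; one five-membered aromatic ring with 1 hetero atom, one six-membered aromatic ring with 1 hetero atom), on a carbonyl carbon. Among the measured compounds shown here, no measured pair shows this exchange alone, and the three measured compounds differ from one another in several places at once, so nothing fixes its size. Compound 4 is expected to give 2000 nM in this assay, between 500 nM and 8000 nM. That estimate means an expected step from compound 2 to compound 4 of a 2.0-fold higher number from compound 2 to compound 4 (0.30 log units; within the scatter), small and toward weaker inhibition, possibly within the scatter.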

Compound 4, half-maximal inhibitory concentration: 8 nM
Estimate against measurement, compound 4: 250-fold (2.40 log units) above; the measured number lies below the stated range.
By their numbers in this assay, from the lowest: compound 4; then compound 1; then compounds 2 and 3 (each within the scatter of the next).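

In this assay, among the compounds shown here, the exchange on the carbonyl carbon gives a 130-fold lower number from compound 2 to compound 4 (2.10 log units; beyond the scatter), the only single-place step here, so this position strongly governs the read-out while the rest of compound 2 stays fixed. The entering group has 0 hydrogen-bond donors where the leaving group has 1 hydrogen-bond donor, so strong inhibition in compound 4 does not need a donor in this group. Nothing measured here explains the step. Going by these compounds, whether oxygen in place of the sulfur would hold this level remains open. So does whether the same exchange would give a similar step in compound 1 or compound 3.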